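The source may hold more compounds than are shown below. What is called first, only, known or untested is meant among the compounds shown, and "the series" means these compounds.

Measured compounds:
- compound 1 `COc1cc(OC)c(-c2coc3cc(OCc4ccc(Br)cc4)ccc3c2=O)cc1OC`: 10000 nM
- compound 2 `COc1cc(OC)c(-c2coc3cc(OCc4ccc(C#N)cc4)ccc3c2=O)cc1OC`: 6180 nM

In a functional assay on U-251 cells (Homo sapiens) for antiproliferative activity, read by MTT assay, with a stated time of 24 h (a higher number here means a weaker inhibitor, a lower number a stronger inhibitor), compound 1 gives 10000 nM and compound 2 gives 6180 nM. Going by the values given here, these are the only two numbers so far, and they sit within the scatter of each other, so compound 2 cannot be ranked apart from compound 1.

The next compound is compound 3 `COc1cc(OC)c(-c2coc3cc(OCc4ccc(C(F)(F)F)cc4)ccc3c2=O)cc1OC`. Among the compounds with values here, it keeps the shared core and changes only one group, with trifluoromethyl in place of cyano on an aromatic carbon.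

Within the data shown here, one measured step bears on this, because it changes the same aromatic carbon: a 1.6-fold lower number from compound 1 to compound 2 (0.21 log units; within the scatter). That swap of bromo for cyano moved the number no further than repeat measurements would. Among the measured compounds shown here, one step is thin evidence, and no measured compound yet carries trifluoromethyl. Even so, nothing here points to a real shift in either direction, so no step beyond the scatter is expected in this assay.

The estimated change is a 1.2-fold higher number from compound 2 to compound 3 (0.08 log units; within the scatter). For compound 3 the expected value is 7500 nM, with an estimated range from 3500 nM to 16000 nM.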

Compound 3, half-maximal inhibitory concentration: 3750 nM
The estimate for compound 3 lay 2.0-fold (0.30 log units) above the measured number, and the stated range covers the measured number.
By their numbers in this assay, from the lowest: compounds 3, 2 and 1 (each within the scatter of the next, the first and the last beyond it).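

Going by these compounds alone, this is the first step on this aromatic carbon to go beyond the scatter: in this assay, trifluoromethyl in place of bromo gives a 2.7-fold lower number from compound 1 to compound 3 (0.43 log units; beyond the scatter), so the choice of group here can move the number, though only modestly. Trifluoromethyl in place of cyano gives a 1.6-fold lower number from compound 2 to compound 3 (0.22 log units; within the scatter), which stays within the scatter, so the nitrile and trifluoromethyl groups cannot be told apart in this assay, and the earlier bromo-to-cyano step could not separate its pair either; only the bromo and trifluoromethyl ends of this short series stand apart. No measured property of these groups is available to explain that gap.

From the compounds shown here alone, all three groups occupy the same aromatic carbon, so it remains open what an amine, a carboxylic acid or a longer chain would do there, and whether any such group would shift the number further than trifluoromethyl does. Going by these compounds, it also remains open whether the gap between the bromo and trifluoromethyl compounds would hold on other cell types or over a different exposure time.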